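One hydroxyphenyl swap on compound 2

The compounds below may be only part of what the source reports. "The series", "measured", "known", "first", "only" and "open" are said of these compounds alone.

- compound 1 `O=C(/C=C/c1cccc(O)c1)CC(=O)/C=C/c1cccc(O)c1O`: 38000 nM
- compound 2 `O=C(/C=C/c1ccccc1O)/C=C/c1cccc(O)c1O`: 54000 nM

In an ADME assay on PC-12 cells (Rattus norvegicus) for cytotoxicity, read by WST assay, with a stated time of 24 h (a higher number here means that more compound is tolerated, a lower number that less compound is tolerated), compound 2 gives 54000 nM and compound 1 gives 38000 nM, so the two stand within the usual scatter of each other. Compound 3 `O=C(/C=C/c1cccc(O)c1)/C=C/c1cccc(O)c1O` has the same atoms as compound 2, joined differently: it carries 3-hydroxyphenyl in place of 2-hydroxyphenyl on a double-bonded chain carbon bound to a double-bonded chain carbon. Within the data shown here, no measured pair shows what this swap does in this assay, so no change beyond the scatter is expected, and the estimated step is a 1.2-fold lower number from compound 2 to compound 3 (0.08 log units; within the scatter). For compound 3 the estimated value is 45000 nM, with an expected range of 20000 nM to 95000 nM.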

Compound 3, half-maximal cytotoxic concentration in the PC-12 assay: 46000 nM
Beside the measured number, compound 3's estimate is 1.0-fold (0.01 log units) below it, within the range that was stated.
By their numbers in the PC-12 assay, from the lowest: compounds 1, 3 and 2 (each within the scatter of the next).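

Among these compounds, this is the first measured step at this place, on a double-bonded chain carbon bound to a double-bonded chain carbon: in the PC-12 assay, compound 3 gives 46000 nM and exchanging 2-hydroxyphenyl for 3-hydroxyphenyl gives a 1.2-fold lower number from compound 2 to compound 3 (0.07 log units; within the scatter). In a physicochemical assay for solubility, using the shake flask method, with a stated time of 12 h (a higher number here means a more soluble compound, a lower number a less soluble compound), compound 2 gives 151000 nM and compound 3 gives 184000 nM and the same exchange gives a 1.2-fold higher number from compound 2 to compound 3 (0.09 log units; within the scatter), so neither read-out separates the two hydroxyphenyl groups. Nothing shown gives a reason for either result. Still open, from the compounds shown here alone, is whether an amine or a carboxylic acid in place of the hydroxyphenyl group would move either number beyond the scatter.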